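The compounds below may be only part of what the source reports. "The series", "measured", "known", "first", "only" and "open" are said of these compounds alone.

Measured in a toxicity assay on HEK-293T cells (Homo sapiens) for cytotoxicity, read by MTT assay, with a stated time of 72 h; on this read-out higher numbers stand for weaker inhibition and lower numbers for stronger inhibition:
- compound 1 `O=C1c2c[n+]([O-])c3ccccc3c2C(=O)c2c1c1ccccc1n2Cc1cn([C@@H]2C[C@H](O)[C@@H](CO)O2)nn1`: 820 nM
- compound 2 `CC1(C)O[C@@H](CO)[C@H](Cn2cc(Cn3c4c(c5ccccc53)C(=O)c3c[n+]([O-])c5ccccc5c3C4=O)nn2)O1`: 120 nM
- compound 3 `CC1(C)OC[C@H](Cn2cc(Cn3c4c(c5ccccc53)C(=O)c3c[n+]([O-])c5ccccc5c3C4=O)nn2)O1`: 100 nM

Compound 3 stands at the low end of these numbers, which means comparatively strong inhibition. Its closest neighbour is barely separated from it: a 1.2-fold lower number from compound 2 to compound 3 (0.08 log units; within the scatter). The next structure, compound 4 `O=C1c2c[n+]([O-])c3ccccc3c2C(=O)c2c1c1ccccc1n2Cc1cn([C@@H]2O[C@H](CO)[C@@H](O)[C@H](O)[C@H]2O)nn1`, keeps the shared core but changes the group on an aromatic nitrogen of a five-membered aromatic ring with 3 nitrogen. It has 3,4,5-trihydroxy-6-(hydroxymethyl)oxan-2-yl in place of (2,2-dimethyl-1,3-dioxolan-4-yl)methyl on an aromatic nitrogen.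

Within the data shown here, the best guide is compound 1, the only measured compound with a hydroxy-bearing ring attached directly at this nitrogen, a 4-hydroxy-5-(hydroxymethyl)oxolan-2-yl group. Replacing that group gave an 8.2-fold lower number from compound 1 to compound 3 (0.91 log units; beyond the scatter) and also a 6.8-fold lower number from compound 1 to compound 2 (0.83 log units; beyond the scatter), both modest steps beyond the scatter. The move to compound 4 runs roughly the opposite way, so a step of similar size towards a higher number is expected in this assay. The expected step is an 8.0-fold higher number from compound 3 to compound 4 (0.90 log units; beyond the scatter). Among the measured compounds shown here, no measured compound has a six-membered ring at this place, which leaves the range wide. For compound 4 the estimated value is 800 nM, with an expected range from 250 nM to 3000 nM.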

Compound 4, half-maximal inhibitory concentration: 940 nM
For compound 4 the middle estimate is 1.2-fold (0.07 log units) below the measured one; the measured number falls inside the stated range.
By their numbers in this assay, from the lowest: compounds 3 and 2 (each within the scatter of the next); then compounds 1 and 4 (each within the scatter of the next).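

In this assay, the six-membered 3,4,5-trihydroxy-6-(hydroxymethyl)oxan-2-yl group on this aromatic nitrogen cannot be told apart from the five-membered 4-hydroxy-5-(hydroxymethyl)oxolan-2-yl group, with a 1.1-fold higher number from compound 1 to compound 4 (0.06 log units; within the scatter), so a change in ring size together with extra hydroxy groups leaves the number within the scatter. Against the two dioxolane compounds the gap is clear, with a 9.4-fold higher number from compound 3 to compound 4 (0.97 log units; beyond the scatter) and a 7.8-fold higher number from compound 2 to compound 4 (0.89 log units; beyond the scatter), so the four compounds now fall into two groups at this position: compounds 1 and 4 at the high end and compounds 2 and 3 at the low end, with nothing in between. No measurement here explains why the two groups differ.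

The two groups differ in more than one feature at once, since compounds 2 and 3 carry a dioxolane ring joined through a methyl link while compounds 1 and 4 carry a ring bonded directly to the nitrogen, so a 2,3-dihydroxypropyl chain would help to separate these features. On these data alone, it also remains open where an amine, a carboxylic acid or a plain butyl chain at this nitrogen would fall.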